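Phenyl to 2-fluorobenzyl on the amide nitrogen

A few compounds are considered here, and "the series" means these few. Any claim that something is new, unique, unknown or untested is made for them only; others in the source may bear on it.

Measured in a functional assay on HeLa cells (Homo sapiens) for inhibition, read by MTT assay, with a stated time of 48 h; a lower number here means a stronger inhibitor, a higher number a weaker inhibitor:
- compound 1 `COc1ccc2c(=O)c(/C=C/C(=O)NCc3ccccc3)coc2c1`: 33400 nM
- compound 2 `COc1ccc2c(=O)c(/C=C/C(=O)Nc3ccccc3)coc2c1`: > 100000 nM, a limit
- compound 3 `COc1ccc2c(=O)c(/C=C/C(=O)NCc3cccc(F)c3)coc2c1`: 17600 nM

Compound 2 has no number, only the limit > 100000 nM. Compound 4 `COc1ccc2c(=O)c(/C=C/C(=O)NCc3ccccc3F)coc2c1` carries 2-fluorobenzyl in place of phenyl on an amide-type nitrogen.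

The closest measured change is an at least 5.6-fold lower number from compound 2 to compound 3 (0.75 log units; beyond the scatter), which has 3-fluorobenzyl as the entering group. Benzyl alone gives an at least 2.9-fold higher number from compound 1 to compound 2 (0.47 log units; beyond the scatter) in the opposite direction. Adding fluoro gives a 1.9-fold lower number from compound 1 to compound 3 (0.28 log units; within the scatter), within the scatter. A lower number of similar size is therefore expected in this assay, with the estimated step being an at least 4.3-fold lower number from compound 2 to compound 4 (0.63 log units; beyond the scatter). For compound 4 the estimate is 23000 nM, with an expected range of 10000 nM to 55000 nM.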

Compound 4, half-maximal inhibitory concentration: > 100000 nM
Compound 4: only a limit was reported (the forecaster's own chance of this, stated with the estimate: 7%); middle value at least 4.3-fold (0.63 log units) away from the limit.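

Swapping 3-fluorobenzyl for 2-fluorobenzyl is not a neutral change in this assay: an at least 5.6-fold higher number from compound 3 to compound 4 (0.75 log units; beyond the scatter). Fluoro on an aromatic carbon of the benzyl group therefore does not give one outcome: compound 3 stays within the scatter of compound 1, while the other fluoro compound shows an at least 2.9-fold higher number from compound 1 to compound 4 (0.47 log units; beyond the scatter). The step from compound 2 to compound 4 cannot be read, both values being limits: the limit of > 100000 nM in this assay, at which 2 of the 4 values shown sit.

From the compounds shown here alone, whether 2-chlorobenzyl or 2-methoxybenzyl on the amide-type nitrogen would behave like 2-fluorobenzyl remains open. So does the effect of a longer chain such as 2-phenylethyl.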